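From propargyl to benzyl on a shared core

The source may hold more compounds than are shown below. What is called first, only, known or untested is meant among the compounds shown, and "the series" means these compounds.

Compound 2, `C#CCSc1nnc(CC)n1N1C(=O)c2ccccc2C1=O`, is one of two close relatives measured in a functional assay on A549 cells (Homo sapiens) for cytotoxicity, read by MTT assay, with a stated time of 48 h; on this read-out lower numbers stand for stronger inhibition and higher numbers for weaker inhibition. In this assay compound 2 gives only a limit, > 200000 nM. Compound 1, `C#CCSc1nnc(C)n1N1C(=O)c2ccccc2C1=O`, likewise gives a limit in this assay, > 200000 nM. Among the measured compounds shown here, the single step between them, a step that the two limits leave unreadable from compound 1 to compound 2, has no readable size because of the limit of > 200000 nM in this assay, at which 2 of the 2 values shown sit. Compound 3, `CCc1nnc(SCc2ccccc2)n1N1C(=O)c2ccccc2C1=O`, differs from compound 2 by phenyl in place of ethynyl on a saturated chain carbon bound to a sulfur. For the measured compounds named here, no measured step covers a change of this kind, and the one step that exists cannot be read, so compound 2 stands only at a limit and offers no direction to build on. The step of an at least 1.3-fold lower number from compound 2 to compound 3 (0.12 log units; that floor lies within the scatter) is therefore expected to be small, in no settled direction, with a fair chance that this assay again reports only a limit. Compound 3 is estimated at 150000 nM, with a range from 30000 nM to 500000 nM.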

Compound 3, half-maximal inhibitory concentration: > 200000 nM
Compound 3: a limit, no number; the forecaster's own chance of this, stated with the estimate: 65%; at least 1.3-fold (0.12 log units) between middle value and limit.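

In this assay compound 3 gives > 200000 nM as a limit and not a number. Among the compounds shown here, compound 2 also stands at a limit, so no step from compound 2 to compound 3 can be read. The compounds shown leave open which change on the shared core, if any, would give a measurable value.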